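Aryl Ether in Place of Thioether on the Shared Core

The source may report more compounds than this note shows. Statements on the series, on what has been measured and on what is new or still open speak of the compounds shown alone.

Compound 3 `Cc1cc(Sc2ccccc2)c(S(C)(=O)=O)cc1C(=O)N=C(N)N` gives 14 nM in a functional assay for inhibition of sodium/hydrogen exchanger (Oryctolagus cuniculus); on this read-out lower numbers stand for stronger inhibition and higher numbers for weaker inhibition. Of the three numbers measured, that of compound 3 is the second highest: compound 1 `Cc1cc(Br)c(S(C)(=O)=O)cc1C(=O)N=C(N)N` gives 12 nM and compound 2 `Cc1cc(C2CCCCC2)c(S(C)(=O)=O)cc1C(=O)N=C(N)N` gives 22 nM. The steps of a 1.2-fold higher number from compound 1 to compound 3 (0.07 log units; within the scatter) and a 1.6-fold lower number from compound 2 to compound 3 (0.20 log units; within the scatter) both lie within the scatter, as does a 1.8-fold higher number from compound 1 to compound 2 (0.26 log units; within the scatter). Compound 4 `Cc1cc(Oc2ccc(Cl)cc2)c(S(C)(=O)=O)cc1C(=O)N=C(N)N` differs from compound 3 in one place: 4-chlorophenoxy in place of phenylsulfanyl on an aromatic carbon. Among the measured compounds shown here, no measured step exchanges phenylsulfanyl for another group carrying a six-membered aromatic ring of carbon only, so the steps that bear on this change are a 1.2-fold higher number from compound 1 to compound 3 (0.07 log units; within the scatter) and a 1.6-fold lower number from compound 2 to compound 3 (0.20 log units; within the scatter), which show that bromo, cyclohexyl and phenylsulfanyl at this aromatic carbon leave the read-out within the scatter of one another. Compound 4 is therefore expected to show no step beyond the scatter, a 1.1-fold higher number from compound 3 to compound 4 (0.03 log units; within the scatter). The estimate for compound 4 is 15 nM, with a range from 6 nM to 40 nM.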

Compound 4, half-maximal inhibitory concentration: 13 nM
Estimate against measurement, compound 4: 1.2-fold (0.06 log units) above; low and high end bracket the measured number.
By their numbers in this assay, from the lowest: compounds 1, 4, 3 and 2 (each within the scatter of the next).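

In this assay, replacing phenylsulfanyl with 4-chlorophenoxy gives a 1.1-fold lower number from compound 3 to compound 4 (0.03 log units; within the scatter) and so brings oxygen in place of sulfur, together with a chlorine on the aromatic ring, without a step beyond the scatter. The same group compared with the other two gives a 1.7-fold lower number from compound 2 to compound 4 (0.23 log units; within the scatter) and a 1.1-fold higher number from compound 1 to compound 4 (0.03 log units; within the scatter) and thus also stays within the scatter of cyclohexyl and bromo. Across the four compounds shown, no group at this aromatic carbon can therefore be separated from any other by this read-out.

On these data alone, the oxygen and the chlorine arrive together in compound 4, so the effect of each alone stays open, and phenoxy or 4-chlorophenylsulfanyl would separate them. Whether an amine, a carboxylic acid or a longer alkyl chain at this carbon would keep the number within the same scatter also stays open, and nothing at hand gives a reason for the level read-out across these groups.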